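Methyl-for-hydrogen steps on the amino side chain

A few compounds are considered here, and "the series" means these few. Any claim that something is new, unique, unknown or untested is made for them only; others in the source may bear on it.

Measured so far in an assay on Cerebral cortex for displacement of a labelled ligand from adenosine receptor A1 (Bos taurus); a higher number here means a weaker inhibitor, a lower number a stronger inhibitor:
compound 1, `CCCNc1nc(-c2ccccc2)nc2c1nnn2Cc1ccccc1F`, gives 3.2 nM
compound 2, `CCCCNc1nc(-c2ccccc2)nc2c1nnn2Cc1ccccc1F`, gives 4.3 nM
compound 3, `OCCNc1nc(-c2ccccc2)nc2c1nnn2Cc1ccccc1Cl`, gives 116 nM

Compound 2 differs from compound 1 by methyl in place of hydrogen on a saturated chain carbon, three bonds along the chain from a nitrogen on an aromatic ring; in this assay this reads a 1.3-fold higher number from compound 1 to compound 2 (0.13 log units; within the scatter). Compound 3 differs from compound 1 in more than one place, and the difference between the two cores is not broken down here; in this assay compound 3 has the highest of the three numbers, nearest to compound 2 and furthest from compound 1.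

Compound 4, `CC(O)CNc1nc(-c2ccccc2)nc2c1nnn2Cc1ccccc1Cl`, is not yet measured. It differs from compound 3 by methyl in place of hydrogen on a saturated chain carbon bound to an oxygen on a saturated carbon and a saturated chain carbon. This is the same kind of change as from compound 1 to compound 2, but the place is not the same: there the methyl enters on a saturated chain carbon, three bonds along the chain from a nitrogen on an aromatic ring; here it enters on a saturated chain carbon bound to an oxygen on a saturated carbon and a saturated chain carbon. The expectation for compound 4 rests on a 1.3-fold higher number from compound 1 to compound 2 (0.13 log units; within the scatter), which lies within the scatter. A step of a 1.1-fold lower number from compound 3 to compound 4 (0.02 log units; within the scatter) is expected in this assay. Compound 4 is thus estimated at 110 nM, with a range from 40 nM to 300 nM.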

Compound 4, inhibition constant: 32 nM
Beside the measured number, compound 4's estimate is 3.4-fold (0.54 log units) above it; measured number below the stated range.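

In this assay the methyl-for-hydrogen change on the 2-hydroxyethyl chain reads a 3.6-fold lower number from compound 3 to compound 4 (0.56 log units; beyond the scatter). Set beside the earlier step on the other core, the same kind of change does not carry over at the same size: the same change on two cores in this assay, a 1.3-fold higher number (0.13 log units; within the scatter) from compound 1 to compound 2 and a 3.6-fold lower number (0.56 log units; beyond the scatter) from compound 3 to compound 4, 4.9-fold (0.69 log units) apart, beyond the scatter of two such steps

Going by these compounds alone, the two steps differ both in core and in the place where the methyl enters, and a single pair on each core cannot separate these two, so the gap shows only that the earlier step was a poor guide here, not which difference accounts for it.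

Still open, from the compounds shown here alone, is whether the change to 2-hydroxypropyl gives a similar step on the core of compound 1, and whether the methyl step seen from compound 1 to compound 2 holds on the core of compound 3. Also open, going by these compounds, is how the number in this assay would respond to an amine or a carboxylic acid in place of the hydroxyl, or to a longer chain carrying the hydroxyl.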